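This account rests on a few compounds, and the source may have more. Where it says the series, first, only, none or still open, it means among the compounds named here.

The measured compounds:
compound 1, `CCN(CC)CCNc1c(-c2ccccc2)c(C)c(C#N)c2nc(C(C)(C)C)nn12`, 3.3;
compound 2, `CCCCc1nc2c(C#N)c(C)c(-c3ccccc3)c(N3CC[C@H](N(C)C)C3)n2n1`, 3.2;
compound 3, `Cc1c(-c2ccccc2)c(N2CC[C@H](N(C)C)C2)n2nc(C(C)(C)C)cc2c1C#N`, 4.8.

In a physicochemical assay for lipophilicity, in phosphate buffer, measured as octanol-water partition, at pH 6.8 (on this read-out lower numbers stand for lower lipophilicity and higher numbers for higher lipophilicity), compound 2 and compound 1 sit within the usual scatter of each other, so nothing separates the two; compound 3 lies beyond the scatter, higher than compound 2. Compound 4, `CCc1nc2c(C#N)c(C)c(-c3ccccc3)c(N3CC[C@H](N(C)C)C3)n2n1`, has not yet been measured in this assay. It differs from compound 2 in one place: hydrogen in place of ethyl on a saturated chain carbon, two bonds along the chain from an aromatic carbon, so the chain on the core shortens from butyl to ethyl. For the measured compounds named here, no step between measured compounds shows such a change, so the expectation rests on the size of what leaves. The expected step is a number 0.90 log units lower from compound 2 to compound 4 (beyond the scatter), downward and beyond the scatter. For compound 4 the estimate in this assay is 2.3, with a range from 1.8 to 2.8.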

Compound 4, distribution coefficient: 2.1
Beside the measured number, compound 4's estimate is 0.20 log units above it; low and high end bracket the measured number.
By their numbers in this assay, from the lowest: compound 4; then compounds 2 and 1 (each within the scatter of the next); then compound 3.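

In this assay, the chain on the core proves to be a place where a single change moves the number: going from butyl to ethyl gives a number 1.10 log units lower from compound 2 to compound 4 (beyond the scatter). For the compounds shown here, this is the first step here that isolates one change, since the earlier compounds differ from each other in more than one place. Nothing at hand accounts for the size of this step.

On these data alone, what a propyl chain, a hexyl chain or a carboxylic acid would give in this place stays open. So does whether a step of this size would recur on another core.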